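Nitro for hydroxy on the uracil carbon of compound 2

A few compounds are considered here, and "the series" means these few. Any claim that something is new, unique, unknown or untested is made for them only; others in the source may bear on it.

Measured compounds and values:
- compound 1, `CCc1cn([C@H]2C[C@H](O)[C@@H](OP(=O)(O)O)O2)c(=O)[nH]c1=O`: 28200000 nM
- compound 2, `O=c1[nH]c(=O)n([C@H]2C[C@H](O)[C@@H](OP(=O)(O)O)O2)cc1O`: 309000000 nM

In an assay on L1210 cells for inhibition of Thymidylate synthase (Mus musculus) (on this read-out higher numbers stand for weaker inhibition and lower numbers for stronger inhibition), compound 2 gives 309000000 nM, the higher of the two numbers in hand. For the measured compounds named here, its only measured neighbour is compound 1, which in this assay gives 28200000 nM; the step of an 11-fold higher number from compound 1 to compound 2 (1.04 log units; beyond the scatter) is the single comparison available for the shared core.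

Compound 3, `O=c1[nH]c(=O)n([C@H]2C[C@H](O)[C@@H](OP(=O)(O)O)O2)cc1[N+](=O)[O-]`, has not been measured in this assay. Relative to compound 2 the change is nitro in place of hydroxy on an aromatic carbon, at the same carbon where the measured step replaced ethyl by hydroxy.

Going by the values given here, the one measured step bears on compound 3 only indirectly: it shows that a swap at this carbon moved the number beyond the scatter, but it does not involve nitro, and nothing in the data fixes the direction for this second swap. A step of comparable size, in either direction, is the reasonable expectation; the estimate for compound 3 is 10000000 nM, with a range from 1000000 nM to 300000000 nM, which corresponds to an expected step of a 31-fold lower number from compound 2 to compound 3 (1.49 log units; beyond the scatter).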

Compound 3, inhibition constant: 2570000 nM
Estimate against measurement, compound 3: 3.9-fold (0.59 log units) above; the measured number falls inside the stated range.
By their numbers in this assay, from the lowest: compound 3; then compound 1; then compound 2.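

In this assay, this aromatic carbon now carries three groups, and nitro gives the lowest number of the three: replacing hydroxy gives (a 120-fold lower number from compound 2 to compound 3 (2.08 log units; beyond the scatter)), and replacing ethyl gives (an 11-fold lower number from compound 1 to compound 3 (1.04 log units; beyond the scatter)). For the compounds shown here, the earlier pair showed only that the number rose when hydroxy replaced ethyl (an 11-fold higher number from compound 1 to compound 2 (1.04 log units; beyond the scatter)); the new compound shows that a change at this carbon can also take the number well below that of compound 1, so ethyl is not the best of the groups seen here. The series therefore runs from nitro through ethyl to hydroxy, with each step beyond the scatter, but no measured property of these groups accompanies the numbers and the order stays unexplained.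

Three groups at one carbon do not show whether a nitrile, a carboxylic acid, an amine or a longer chain would fall below or above nitro on this read-out. It also stays open whether nitro in place of hydroxy gives a step of similar size on any core other than the shared core of these compounds.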